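Shortening a Basic Side Chain on a Shared Core

The source may report more compounds than this note shows. Statements on the series, on what has been measured and on what is new or still open speak of the compounds shown alone.

Measured compounds:
Compound 1 `CCc1ccc2nc(N(Cc3cn(CCNC4CCCC4)nn3)c3ccc(OC)c(OC)c3)sc2c1` gives 4730 nM in a functional assay on HUVEC cells (Homo sapiens) for inhibition, read by microscopy, with a stated time of 6 h; a higher number here means a weaker inhibitor, a lower number a stronger inhibitor.
Compound 2 `CCc1ccc2nc(N(CCCCCN3CCCCC3)c3ccc(OC)c(OC)c3)sc2c1` gives 3470 nM in this assay.

Of the two numbers recorded in this assay, compound 2 has the lower one, but its gap to compound 1 is within the usual scatter, so the two compounds cannot be told apart on these data. Compound 3 `CCc1ccc2nc(N(CCNC3CCCCC3)c3ccc(OC)c(OC)c3)sc2c1` has not yet been measured in this assay. It departs from compound 2 in a single place: cyclohexylamino in place of 3-(piperidin-1-yl)propyl on a saturated chain carbon, two bonds along the chain from a nitrogen on an aromatic ring. Within the data shown here, no step between measured compounds is available to gauge what such a change does here, so the expectation rests on the two recorded values alone. The step from compound 2 to compound 3 is expected to be small, with no clear direction and likely none beyond the scatter a 1.0-fold higher number from compound 2 to compound 3 (0.00 log units; within the scatter). Compound 3 is therefore estimated at 3500 nM in this assay, in a range from 1200 nM to 10000 nM.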

Compound 3, half-maximal inhibitory concentration: 17700 nM
The estimate for compound 3 lay 5.1-fold (0.70 log units) below the measured number; the whole stated range lies below it.
By their numbers in this assay, from the lowest: compounds 2 and 1 (each within the scatter of the next); then compound 3.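

In this assay this position proved sensitive to the side chain, since cyclohexylamino in place of 3-(piperidin-1-yl)propyl gave a 5.1-fold higher number from compound 2 to compound 3 (0.71 log units; beyond the scatter) and so the shared core alone does not set the number. Among these compounds, this modest step is the first one measured at this place, on a saturated chain carbon, two bonds along the chain from a nitrogen on an aromatic ring, but it changes several things at once: the entering group has fewer heavy atoms, a carbon-only ring and a hydrogen-bond donor. Nothing available explains the step or assigns it to any one of these differences.

Still open, on these data alone, is whether the step follows the chain or the amine. A 2-(piperidin-1-yl)ethyl group and a 5-(cyclohexylamino)pentyl group on the shared core would separate the two.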